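The source may hold more compounds than are shown below. What is called first, only, known or untested is meant among the compounds shown, and "the series" means these compounds.

- Compound 1 `COc1cccc(C(=O)Oc2ccc3c(=O)c(-c4cc(OC)c(OC)cc4OC)coc3c2)c1`: > 10000 nM, a limit rather than a number
- Compound 2 `COc1cc(OC)c(-c2coc3cc(OCc4ccccc4C)ccc3c2=O)cc1OC`: 1860 nM
- Compound 3 `COc1cc(OC)c(-c2coc3cc(OCc4ccccc4C(F)(F)F)ccc3c2=O)cc1OC`: 6550 nM

In a functional assay on HepG2 cells (Homo sapiens) for antiproliferative activity, read by MTT assay, with a stated time of 24 h (on this read-out higher numbers stand for weaker inhibition and lower numbers for stronger inhibition), compound 3 has the higher of the two actual numbers, at 6550 nM. Compound 4 `COc1cc(OC)c(-c2coc3cc(OCc4cccc(Cl)c4)ccc3c2=O)cc1OC` has 3-chlorophenyl in place of 2-(trifluoromethyl)phenyl on a saturated chain carbon bound to an oxygen on an aromatic ring.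

The most relevant measured change is a 3.5-fold higher number from compound 2 to compound 3 (0.55 log units; beyond the scatter), where trifluoromethyl replaces methyl on an aromatic carbon. Losing the trifluoromethyl group may therefore bring some of that difference back, although no measured step involves chlorine. The expected change is small and toward stronger inhibition, namely a 2.2-fold lower number from compound 3 to compound 4 (0.34 log units; beyond the scatter). The estimate for compound 4 is 3000 nM, with an expected range from 1000 nM to 9000 nM.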

Compound 4, half-maximal inhibitory concentration: 750 nM
Compound 4: the middle estimate sits 4.0-fold (0.60 log units) above what was measured, and the stated range ends above it.
By their numbers in this assay, from the lowest: compound 4; then compound 2; then compound 3. At a limit, above all of these: compound 1.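

In this assay, changing the group at this position can strengthen inhibition as well as weaken it: 3-chlorobenzyl outdoes both 2-(trifluoromethyl)benzyl (an 8.7-fold lower number from compound 3 to compound 4 (0.94 log units; beyond the scatter)) and 2-methylbenzyl (a 2.5-fold lower number from compound 2 to compound 4 (0.39 log units; beyond the scatter)). The gain over (3-methoxyphenyl)carbonyl is large (an at least 13-fold lower number from compound 1 to compound 4 (1.12 log units; beyond the scatter)), but it is only a floor, set by a limit: the limit of > 10000 nM in this assay, at which 1 of the 4 values shown sits.

Still open, going by these compounds, is whether the chlorine or its place on the ring gives the gain, as both change at once in these steps. On these data alone, how an amine or a carboxylic acid on the benzyl ring would behave also remains open.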